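The source may report more compounds than this note shows. Statements on the series, on what has been measured and on what is new or still open speak of the compounds shown alone.

Compound 1 `CCCSc1nc(N/N=C(\C)c2ccccc2O)c2nnn(Cc3ccc(Cl)cc3)c2n1` gives 42600 nM in a functional assay on MCF7 cells (Homo sapiens) for antiproliferative activity, read by MTT assay, with a stated time of 72 h; on this read-out lower numbers stand for stronger inhibition and higher numbers for weaker inhibition. Compound 2 `CCCSc1nc(N/N=C(\C)c2ccc(O)cc2)c2nnn(Cc3ccccc3)c2n1`, which carries its hydroxyl and benzyl groups differently, gives 21600 nM in this assay. For compound 3 `CCCSc1nc(N/N=C(\C)c2ccccc2O)c2nnn(Cc3ccc(F)cc3)c2n1` only a limit is known in this assay, > 64000 nM, which is the limit of > 64000 nM in this assay, at which 1 of the 3 values shown sits. Compound 4 `CCCSc1nc(N/N=C(\C)c2ccccc2O)c2nnn(Cc3ccccc3)c2n1` has not yet been measured. Going by the values given here, the single measured step that bears on the change leading to it is an at least 1.5-fold higher number from compound 1 to compound 3 (0.17 log units; that floor lies within the scatter); in compound 4 (hydrogen in place of fluoro on an aromatic carbon). Since that step only shows that fluoro did not improve on chloro, and its floor lies within the scatter, compound 4 is expected to shift by an at least 1.0-fold lower number from compound 3 to compound 4 (0.02 log units; that floor lies within the scatter) in this assay, with a real chance that only a limit is reported. Compound 4 is estimated at 60000 nM, between 25000 nM and 150000 nM.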

Compound 4, half-maximal inhibitory concentration: 11000 nM
The estimate for compound 4 lay 5.5-fold (0.74 log units) above the measured number; measured number below the stated range.
By their numbers in this assay, from the lowest: compounds 4, 2 and 1 (each within the scatter of the next, the first and the last beyond it). At a limit, above all of these: compound 3.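

In this assay, hydrogen on this aromatic carbon gives a lower number than either halogen, which the earlier comparison of chloro with fluoro could not show: there is an at least 5.8-fold lower number from compound 3 to compound 4 (0.76 log units; beyond the scatter), and a 3.9-fold lower number from compound 1 to compound 4 (0.59 log units; beyond the scatter). With benzyl in place, the hydroxyl change gives a 2.0-fold lower number from compound 2 to compound 4 (0.29 log units; within the scatter), so 2-hydroxyphenyl and 4-hydroxyphenyl are not told apart here. The first of these steps rests on a limit, not a number: the limit of > 64000 nM in this assay, at which 1 of the 4 values shown sits.

Open, from the compounds shown here alone, is what a methyl or methoxy group on this aromatic carbon would do, and how far chloro and fluoro truly differ.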